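Replacing the 4-vinylphenyl group of compound 3

This account rests on a few compounds, and the source may have more. Where it says the series, first, only, none or still open, it means among the compounds named here.

In a functional assay on HeLa cells (Homo sapiens) for inhibition, read by CCK-8 assay, with a stated time of 48 h (on this read-out lower numbers stand for stronger inhibition and higher numbers for weaker inhibition), compound 1 `COc1cc(-c2ccnc3cc(-c4ccc(C)cc4)nn23)cc(OC)c1OC` gives 21 nM, compound 2 `COc1cc(-c2ccnc3cc(-c4ccc(C)c(C)c4)nn23)cc(OC)c1OC` gives 241 nM and compound 3 `C=Cc1ccc(-c2cc3nccc(-c4cc(OC)c(OC)c(OC)c4)n3n2)cc1` gives 882 nM. Compound 3 therefore has the highest number of the three, which makes it the weakest inhibitor here.

Compound 4 `COc1ccc(-c2cc3nccc(-c4cc(OC)c(OC)c(OC)c4)n3n2)cc1N` has not been measured yet. It keeps the shared core but carries 3-amino-4-methoxyphenyl in place of 4-vinylphenyl, on an aromatic carbon of a five-membered aromatic ring with 2 nitrogen. The difference is 3-amino-4-methoxyphenyl in place of 4-vinylphenyl on an aromatic carbon.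

All three measured steps concern this same aromatic group. They are an 11-fold higher number from compound 1 to compound 2 (1.06 log units; beyond the scatter), a 42-fold higher number from compound 1 to compound 3 (1.62 log units; beyond the scatter) and a 3.7-fold higher number from compound 2 to compound 3 (0.56 log units; beyond the scatter). Even small edits there have moved the number clearly, and both other compounds lie below compound 3, so a large drop is expected rather than a rise. Among the compounds with values here, no measured compound carries 3-amino-4-methoxyphenyl, which leaves the range wide.

The expected change is a 15-fold lower number from compound 3 to compound 4 (1.17 log units; beyond the scatter). For compound 4 the estimated value is 60 nM, with an expected range of 8 nM to 400 nM.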

Compound 4, half-maximal inhibitory concentration: 283 nM
The estimate for compound 4 lay 4.7-fold (0.67 log units) below the measured number; low and high end bracket the measured number.
By their numbers in this assay, from the lowest: compound 1; then compounds 2 and 4 (each within the scatter of the next); then compound 3.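

In this assay, putting 3-amino-4-methoxyphenyl in place of 4-vinylphenyl gives a 3.1-fold lower number from compound 3 to compound 4 (0.49 log units; beyond the scatter), so this position can hold a group carrying nitrogen and oxygen and still give a lower number than the vinyl compound. The new group cannot be told apart from 3,4-dimethylphenyl, with a 1.2-fold higher number from compound 2 to compound 4 (0.07 log units; within the scatter), but it does not reach the 4-methylphenyl result, with a 13-fold higher number from compound 1 to compound 4 (1.13 log units; beyond the scatter). Nothing measured here explains these differences.

The amino and methoxy groups enter together in compound 4, so their separate contributions cannot be read from these compounds. As far as these compounds go, whether a phenyl ring carrying only an amino group or only a methoxy group would come closer to compound 1 stays open, as does the effect of a carboxylic acid or a longer chain on that ring.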